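The compounds below may be only part of what the source reports. "The series", "measured", "known", "first", "only" and "open" are said of these compounds alone.

Measured so far in a functional assay on SK-MEL-28 cells (Homo sapiens) for cytotoxicity, read by MTT assay, with a stated time of 3 days; on this read-out higher numbers stand for weaker inhibition and lower numbers for stronger inhibition:
- compound 1 `N#Cc1c(NN)nc(SCc2nc3ccccc3[nH]2)nc1-c1ccccc1` gives 3 nM here
- compound 2 `CN1CCN(c2nc(SCc3nc4ccccc4[nH]3)nc(-c3ccccc3)c2C#N)CC1` gives 20 nM here

Compound 2 holds the higher of the two numbers. Compound 3 `N#Cc1c(-c2ccccc2)nc(SCc2nc3ccccc3[nH]2)nc1N1CCN(S(=O)(=O)c2ccccc2[N+](=O)[O-])CC1` keeps the core of compound 2 and carries (2-nitrophenyl)sulfonyl in place of methyl on an amine nitrogen in a ring, counted as (2-nitrophenyl)sulfonyl in place of methyl on an amine nitrogen in a ring in full. For the measured compounds named here, no measured step touches this nitrogen. Going by the values given here, only one step bears on the change, and only loosely: a 6.7-fold higher number from compound 1 to compound 2 (0.82 log units; beyond the scatter) is a modest step, beyond the scatter, and it brought in the 4-methylpiperazin-1-yl group that is now altered. A step of similar modest size towards a higher number in this assay is therefore expected, with wide uncertainty. The expected step is a 2.5-fold higher number from compound 2 to compound 3 (0.40 log units; beyond the scatter) in this estimate. In this assay the estimate for compound 3 is 50 nM with an expected range from 10 nM to 250 nM.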

Compound 3, half-maximal inhibitory concentration: 8.9 nM
For compound 3 the middle estimate is 5.6-fold (0.75 log units) above the measured one; the whole stated range lies above it.
By their numbers in this assay, from the lowest: compound 1; then compound 3; then compound 2.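

Replacing methyl with (2-nitrophenyl)sulfonyl on the amine nitrogen in the ring gives a 2.2-fold lower number from compound 2 to compound 3 (0.35 log units; beyond the scatter) in this assay. For the compounds shown here, this is the first direct reading at this nitrogen, and it shows that a group of 12 heavy atoms with its own aromatic ring is accepted here in place of a single carbon, with the number moving towards stronger inhibition rather than weaker. Nothing available accounts for the direction or size of this step.

This single pair leaves open whether the step belongs to the sulfonyl link, the phenyl ring or the nitro group. Plain phenylsulfonyl, a 2-aminophenylsulfonyl group or a benzyl group on the same nitrogen would begin to separate these parts.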